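Fluoro for chloro on the benzyl ring: compound 4

The compounds below may be only part of what the source reports. "The series", "measured", "known", "first", "only" and "open" are said of these compounds alone.

Measured in a functional assay on QGY7701 cells (Homo sapiens) for cytotoxicity, read by MTT assay, with a stated time of 48 h; a lower number here means a stronger inhibitor, a higher number a weaker inhibitor:
compound 1 `O=c1ccoc2cc(OCc3cn(Cc4ccc(Cl)cc4)nn3)ccc12` gives 41700 nM
compound 2 `O=c1ccoc2cc(OCc3cn(Cc4ccc(F)cc4)nn3)ccc12` gives 14400 nM
compound 3 `O=c1ccoc2cc(OCc3cn(Cc4ccccc4Cl)nn3)ccc12` gives 19700 nM

Compound 4 `O=c1ccoc2cc(OCc3cn(Cc4ccccc4F)nn3)ccc12` is not yet measured. It differs from compound 3 by fluoro in place of chloro on an aromatic carbon. The same change has been made once before, from compound 1 to compound 2, as fluoro in place of chloro on an aromatic carbon, and there it gave a 2.9-fold lower number from compound 1 to compound 2 (0.46 log units; beyond the scatter). The two cores differ as 2-chlorophenyl in place of 4-chlorophenyl on a saturated chain carbon bound to an aromatic nitrogen, and the step from compound 1 to compound 3 was a 2.1-fold lower number from compound 1 to compound 3 (0.33 log units; beyond the scatter). The place lines are not the same: in compound 1 the halogen sits para to a large group, in compound 3 ortho to a large group, so this is the same kind of change, not the same change. Compound 2 and compound 3 lie within the scatter of each other, a 1.4-fold higher number from compound 2 to compound 3 (0.14 log units; within the scatter).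

With one prior example, the expected step from compound 3 to compound 4 in this assay is a 2.0-fold lower number from compound 3 to compound 4 (0.29 log units; within the scatter), somewhat smaller than the earlier one because the position differs and because a 2.9-fold lower number from compound 1 to compound 2 (0.46 log units; beyond the scatter) is itself only modest. Compound 4 is estimated at 10000 nM, expected between 4000 nM and 25000 nM.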

Compound 4, half-maximal inhibitory concentration: 36900 nM
Compound 4: middle estimate off by 3.7-fold (0.57 log units), on the low side; the measured number lies above the stated range.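

In this assay, fluoro in place of chloro does not carry over from the core of compound 1 to the core of compound 3, and the gap between the two steps exceeds what scatter would give: the same change on two cores in this assay, a 2.9-fold lower number (0.46 log units; beyond the scatter) from compound 1 to compound 2 and a 1.9-fold higher number (0.27 log units; within the scatter) from compound 3 to compound 4, 5.4-fold (0.73 log units) apart, beyond the scatter of two such steps. On the 2-chlorobenzyl to 2-fluorobenzyl pair the step itself stays within the scatter (a 1.9-fold higher number from compound 3 to compound 4 (0.27 log units; within the scatter)), while 2-fluorophenyl in place of 4-fluorophenyl is a modest step beyond it (a 2.6-fold higher number from compound 2 to compound 4 (0.41 log units; beyond the scatter)), and the 2-fluorophenyl and 4-chlorophenyl compounds cannot be told apart (a 1.1-fold lower number from compound 1 to compound 4 (0.05 log units; within the scatter)). With a single pair on each core, this shows only that the gain seen for the 4-substituted pair cannot be assumed for the 2-substituted pair; it does not show why the two differ, nor does it give a rule for the halogen swap in general.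

Still open, from the compounds shown here alone, is whether a bromo or methoxy group on the benzyl ring would follow either step. Also open, going by these compounds, is how an amine or a carboxylic acid at that place would read in this assay.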